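This account rests on a few compounds, and the source may have more. Where it says the series, first, only, none or still open, it means among the compounds named here.

Measured compounds:
- compound 1, `O=c1ccc(CO)nn1Cc1ccccc1`: in a functional assay on aorta (Rattus norvegicus) (on this read-out higher numbers stand for weaker inhibition and lower numbers for stronger inhibition), compound 1 reaches only a limit of the assay, > 100000 nM.
- compound 2, `O=c1ccc(COCc2ccccc2)nn1Cc1ccccc1`: in this assay compound 2 gives 35300 nM.

For the measured compounds named here, compound 2 holds the only actual number in this assay; the other value, for compound 1, is a limit, (the limit of > 100000 nM in this assay, at which 1 of the 2 values shown sits). Going by the values given here, the single measured step, an at least 2.8-fold lower number from compound 1 to compound 2 (0.45 log units; beyond the scatter), concerns the oxygen on the saturated carbon and not the substituent on the aromatic nitrogen. Compound 3, `Cn1nc(COCc2ccccc2)ccc1=O`, differs from compound 2 by hydrogen in place of phenyl on a saturated chain carbon bound to an aromatic nitrogen. Among the compounds with values here, no measured step touches this place, so the direction of the change is open; both measured compounds show only weak inhibition. The estimated step is a 1.7-fold higher number from compound 2 to compound 3 (0.23 log units; within the scatter), a small shift toward a higher number. Compound 3 is expected in this assay at 60000 nM, with a range from 20000 nM to 150000 nM, and a fair chance that only a limit is reported.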

Compound 3, half-maximal inhibitory concentration: > 100000 nM
Compound 3 was reported as a limit; the forecaster's own chance of this, stated with the estimate: 40%; at least 1.6-fold (0.22 log units) between middle value and limit.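

The substituent on the aromatic nitrogen, untouched by the earlier step, now has a measured effect in this assay: benzyl to methyl gives an at least 2.8-fold higher number from compound 2 to compound 3 (0.45 log units; beyond the scatter). The phenyl on the saturated chain carbon bound to an aromatic nitrogen therefore counts towards the measured inhibition of compound 2, and the benzyl on the oxygen, which compound 3 keeps, does not give a measurable number without it. The full size of the step stays unfixed, because the value of compound 3 is a limit and not a number: the limit of > 100000 nM in this assay, at which 2 of the 3 values shown sit.

On these data alone, what an ethyl, a longer chain or a chain ending in an amine would do on this nitrogen stays open. So does whether a phenyl carrying a fluorine or a methoxy group would take the number lower than in compound 2, which gives 35300 nM.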